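Replacing the Anilide Phenyl with a Hydroxymethyl-Thiazole

This account rests on a few compounds, and the source may have more. Where it says the series, first, only, none or still open, it means among the compounds named here.

Measured compounds:
compound 1, `COc1ccc(C(=O)Nc2nc(CN)cs2)cc1`, 50 ug/mL
compound 2, `CC(C)(C)c1cc(C(=O)Nc2ccccc2)n(Cc2ccccc2)n1`, 1.6 ug/mL

Of the compounds shown here, two have been measured in a physicochemical assay for solubility, read by nephelometry, measured as kinetic solubility, at pH 2.0; a lower number here means a less soluble compound, a higher number a more soluble compound. Compound 1, `COc1ccc(C(=O)Nc2nc(CN)cs2)cc1`, gives 50 ug/mL. Compound 2, `CC(C)(C)c1cc(C(=O)Nc2ccccc2)n(Cc2ccccc2)n1`, gives 1.6 ug/mL, the lower of the two numbers, and the gap to compound 1 is well beyond the scatter of this assay. Among the measured compounds shown here, the two share an amide but differ throughout the rest of the structure, so no single step connects them.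

Compound 3, `CC(C)(C)c1cc(C(=O)Nc2nc(CO)cs2)n(Cc2ccccc2)n1`, has not yet been measured. It differs from compound 2 in one place: 4-(hydroxymethyl)-1,3-thiazol-2-yl in place of phenyl on an amide-type nitrogen. The thiazole bearing a hydroxymethyl group recalls the thiazole of compound 1, but the cores remain different, so compound 1 serves only as a loose reference point.

For compound 3 a step upward from compound 2 is expected in this assay, of a size beyond the scatter, a 6.3-fold higher number from compound 2 to compound 3 (0.80 log units; beyond the scatter). Compound 3 is therefore estimated at 10 ug/mL, with a plausible range from 3 ug/mL to 40 ug/mL.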

Compound 3, solubility: 12.5 ug/mL
For compound 3 the middle estimate is 1.3-fold (0.10 log units) below the measured one; the range from low to high includes it.
By their numbers in this assay, from the lowest: compound 2; then compound 3; then compound 1.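

Among the compounds shown here, on the amide-type nitrogen of the shared core, 4-(hydroxymethyl)-1,3-thiazol-2-yl in place of phenyl gives a 7.8-fold higher number from compound 2 to compound 3 (0.89 log units; beyond the scatter) in this assay, the first sign that the number at this position responds to a change in one group, which compound 1 and compound 2 could not show because they differ throughout. The change replaces a six-membered aromatic ring of carbon only with a five-membered aromatic ring with 2 hetero atoms and brings in the hydroxymethyl at the same time, so the step belongs to the whole group and cannot be divided between the ring and the hydroxymethyl. Nothing available here bears on what lies behind the step.

Going by these compounds, it remains open whether an unsubstituted 1,3-thiazol-2-yl would keep this step, and whether a carboxylic acid or a dimethylamino group in place of the hydroxymethyl would move the number further. For the compounds shown here, it also remains open whether the same exchange would give a step of similar size on another core, since only one pair of compounds carries it.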